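The compounds below may be only part of what the source reports. "The series", "measured", "known", "first", "only" and "open" are said of these compounds alone.

Among the measured compounds shown here, compound 2 `COc1cc2c(Oc3ccc(NC(=O)c4cn(-c5ccccc5C)nn4)cc3F)ccnc2cc1OCCCN1CCCCC1` gives 1340 nM in a functional assay on HT-29 cells (Homo sapiens) for cytotoxicity, read by MTT assay, with a stated time of 72 h (on this read-out lower numbers stand for stronger inhibition and higher numbers for weaker inhibition), the highest of the three numbers measured so far: compound 1 `COc1cc2c(Oc3ccc(NC(=O)c4cn(-c5ccccc5)nn4)cc3F)ccnc2cc1OCCCN1CCCCC1` gives 180 nM and compound 3 `COc1cc2c(Oc3ccc(NC(=O)c4cn(-c5ccc(F)c(F)c5)nn4)cc3F)ccnc2cc1OCCCN1CCCCC1` gives 210 nM. The steps of a 7.4-fold higher number from compound 1 to compound 2 (0.87 log units; beyond the scatter) and a 6.4-fold lower number from compound 2 to compound 3 (0.80 log units; beyond the scatter) set compound 2 apart from both, whereas the step of a 1.2-fold higher number from compound 1 to compound 3 (0.07 log units; within the scatter) does not separate its two compounds. Compound 4 `COc1cc2c(Oc3ccc(NC(=O)c4cn(-c5ccccc5C)nn4)cc3F)ccnc2cc1OCCCN1CCN(C)CC1` differs from compound 2 by 4-methylpiperazin-1-yl in place of piperidin-1-yl on a saturated chain carbon, three bonds along the chain from an oxygen on an aromatic ring. For the measured compounds named here, none of the measured steps touches this part of the molecule; all three change the ring on the aromatic nitrogen, so nothing measured bears on the present change. Without such a guide, no step beyond the scatter is expected in this assay in either direction. Compound 4 is therefore estimated at 1340 nM, within 450 nM to 4000 nM. The expected step is no change at the digits printed from compound 2 to compound 4 (within the scatter).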

Compound 4, half-maximal inhibitory concentration: 1430 nM
Beside the measured number, compound 4's estimate is 1.1-fold (0.03 log units) below it; low and high end bracket the measured number.
By their numbers in this assay, from the lowest: compounds 1 and 3 (each within the scatter of the next); then compounds 2 and 4 (each within the scatter of the next).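

Among the compounds shown here, the 3-(piperidin-1-yl)propyl group is changed here for the first time, and in this assay the result is a 1.1-fold higher number from compound 2 to compound 4 (0.03 log units; within the scatter), so this assay does not separate 3-(4-methylpiperazin-1-yl)propyl from it carrying 2-methylphenyl. The high number of compound 2 therefore persists through a change at this second site. No available evidence offers an explanation for this result.

On these data alone, whether the same exchange holds with the phenyl of compound 1 or the 3,4-difluorophenyl of compound 3 remains open. Also open, as far as these compounds go, is how a morpholine, a dimethylamino group or a longer chain would read at this position.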